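Removing the Hydroxy Group from Compound 2

The source may hold more compounds than are shown below. What is called first, only, known or untested is meant among the compounds shown, and "the series" means these compounds.

In a functional assay on SK-OV-3 cells (Homo sapiens) for cytotoxicity, read by spectrophotometry, with a stated time of 72 h (a lower number here means a stronger inhibitor, a higher number a weaker inhibitor), compound 2 (`COc1ccc(-c2cccc(=O)n2-c2cc(OC)c(OC)c(OC)c2)cc1O`) gives < 10 nM, which is a limit of the assay and not a number. Compound 1 (`COc1ccc(-c2cccc(=O)n2-c2cc(OC)c(OC)c(OC)c2)cc1OCc1ccccc1`) carries a benzyl on the oxygen where compound 2 has its hydroxy. Compound 1 gives 2310 nM. Among the measured compounds shown here, the one measured step is large: an at least 230-fold lower number from compound 1 to compound 2 (2.36 log units; beyond the scatter), with hydrogen in place of benzyl on that oxygen. Compound 3 (`COc1ccc(-c2cccc(=O)n2-c2cc(OC)c(OC)c(OC)c2)cc1`) goes further and loses the oxygen itself: hydrogen in place of hydroxy on an aromatic carbon. This is hydrogen in place of hydroxy on an aromatic carbon, turning 3-hydroxy-4-methoxyphenyl into 4-methoxyphenyl. The measured step shows that this spot matters, but it does not test the loss of the hydroxy, so it guides direction better than size. The expected change in this assay is an at least 6.0-fold higher number from compound 2 to compound 3 (0.77 log units; beyond the scatter), a weakening smaller than the measured step. For compound 3 the estimated value is 60 nM, with an expected range of 10 nM to 400 nM.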

Compound 3, half-maximal inhibitory concentration: < 10 nM
Compound 3 was reported as a limit; the forecaster's own chance of this, stated with the estimate: 15%; middle value at least 6.0-fold (0.77 log units) from the limit.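

In this assay compound 3 gives < 10 nM, which is a limit of the assay and not a number. The earlier compounds shown here showed only that a benzyl on this oxygen goes with a much weaker result; this one shows that the hydroxy is not needed to reach the limit, and removing the whole benzyloxy group gives an at least 230-fold lower number from compound 1 to compound 3 (2.36 log units; beyond the scatter). The step between compound 2 and compound 3 cannot be read, because both compounds stop at the same limit: the limit of < 10 nM in this assay, at which 2 of the 3 values shown sit.

As far as these compounds go, whether the hydroxy adds anything beyond that limit therefore stays open. Also open, from the compounds shown here alone, is how an amine or a methoxy group on this aromatic carbon would compare, and so how large a group can sit here before the number rises.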